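The source may hold more compounds than are shown below. What is called first, only, known or untested is meant among the compounds shown, and "the series" means these compounds.

Compound 3 `CC1=C/C(=C\C#CCCO)C(=O)C(C)(O)C12CC2` gives 2000 nM in a functional assay on A-375 cells (Homo sapiens) for antiproliferative activity (a lower number here means a stronger inhibitor, a higher number a weaker inhibitor), the higher of the two plain numbers shown. Compound 1 `CC1=C/C(=C\C(C)C)C(=O)C(C)(O)C12CC2` gives 130 nM in this assay, and the step of a 15-fold higher number from compound 1 to compound 3 (1.19 log units; beyond the scatter) is large. Compound 2 `CC1=C/C(=C\c2cccs2)C(=O)C(C)(O)C12CC2` reaches only the limit of this assay, > 10000 nM. Compound 4 `C=C/C=C1\C=C(C)C2(CC2)C(C)(O)C1=O` differs from compound 3 in one place: vinyl in place of 4-hydroxybut-1-yn-1-yl on a double-bonded chain carbon bound to a double-bonded ring carbon. The step of a 15-fold higher number from compound 1 to compound 3 (1.19 log units; beyond the scatter) is the closest guide: there the 4-hydroxybut-1-yn-1-yl group entered in place of isopropyl, and compound 4 reverses that, putting vinyl, another small hydrocarbon group, in its place. A large step downward is therefore expected, roughly an 8.0-fold lower number from compound 3 to compound 4 (0.90 log units; beyond the scatter). Compound 4 is expected to give about 250 nM in this assay, within 60 nM to 1000 nM.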

Compound 4, half-maximal inhibitory concentration: 18 nM
The estimate for compound 4 lay 14-fold (1.14 log units) above the measured number, outside the stated range (below it).
By their numbers in this assay, from the lowest: compound 4; then compound 1; then compound 3. At a limit, above all of these: compound 2.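

Vinyl outperforms isopropyl at this place, with a 7.2-fold lower number from compound 1 to compound 4 (0.86 log units; beyond the scatter), so isopropyl does not mark the best result this position can give. The 4-hydroxybut-1-yn-1-yl group and thiophen-2-yl both lag far behind vinyl, with a 110-fold lower number from compound 3 to compound 4 (2.05 log units; beyond the scatter) and an at least 550-fold lower number from compound 2 to compound 4 (2.74 log units; beyond the scatter), so the group chosen here can change the result greatly. Compound 2 stands at a limit, not a number: the limit of > 10000 nM in this assay, at which 1 of the 4 values shown sits.

The compounds shown do not separate the effect of the hydroxyl from that of chain length in the 4-hydroxybut-1-yn-1-yl group. A plain but-1-yn-1-yl group would address this, and an ethyl group would test whether the double bond of vinyl matters.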